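Series notes: rearranged side chain in compound 4

The source may report more compounds than this note shows. Statements on the series, on what has been measured and on what is new or still open speak of the compounds shown alone.

Measured so far in a functional assay on the whole organism with Rattus norvegicus as the target, at a dose of 100 mg/kg; on this read-out higher numbers stand for more inhibition at the one dose given (going by the name of the read-out) and lower numbers for less inhibition:
compound 1 `CC/N=C(/NC#N)NCCCn1nc(-c2ccccc2)cc(C)c1=O` gives 23.5%
compound 2 `CC/N=C(/NC#N)NCCCn1nc(-c2ccccc2)ccc1=O` gives 62.9%
compound 3 `CC/N=C(/NC#N)NCCCCn1nc(-c2ccccc2)c(C)cc1=O` gives 38.8%

Compound 1 stands lowest of the three numbers in this assay. Compound 3 is nearest to it, a difference beyond the scatter, and compound 2 is furthest, also beyond the scatter. Among the measured compounds shown here, the only step between compounds differing in one place is a number 39.4 percentage points higher from compound 1 to compound 2 (beyond the scatter); it concerns a ring substituent and not the side chain.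

Compound 4 `C/N=C(/NC#N)NCCCCn1nc(-c2ccccc2)cc(C)c1=O` is not yet measured. It differs from compound 1 by a group of 8 heavy atoms (4 carbon, 4 nitrogen; no ring) in place of a group of 8 heavy atoms (4 carbon, 4 nitrogen; no ring), on a saturated chain carbon, three bonds along the chain from an aromatic nitrogen; the two compounds have the same atoms, joined differently. For the measured compounds named here, no measured step bears directly on this change. The step from compound 1 to compound 2 alters the ring, not the chain, and compound 3 differs from compound 1 in two places. Going by the values given here, its value shows only that compound 3, with the longer chain, reaches 38.8%. Compound 1 gives 23.5%. With nothing comparable measured, only a small step is expected for compound 4, a number 6.5 percentage points higher from compound 1 to compound 4 (within the scatter), without a firm direction. Compound 4 is therefore estimated at 30%, within a range from 8% to 58%.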

Compound 4, a percentage reported as inhibition, in the whole organism at one dose (the size of the read-out at that dose, not a potency): 68.6%
For compound 4 the middle estimate is 38.6 percentage points below the measured one; the measured number lies above the stated range.
By their numbers in this assay, from the lowest: compound 1; then compound 3; then compounds 2 and 4 (each within the scatter of the next).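

The side chain is not a silent region in this assay: the earlier single-place step touched only a ring substituent, whereas a number 45.1 percentage points higher from compound 1 to compound 4 (beyond the scatter) comes from a change on a saturated chain carbon, three bonds along the chain from an aromatic nitrogen. The group that leaves and the group that enters have identical counts of heavy atoms, double and triple bonds, hydrogen-bond donors and acceptors, and net charge, so in this pair the read-out follows how the same atoms are joined and not anything those counts capture. No measurement given here accounts for the size of this step.

The rearrangement changes the chain and its terminal group together, so the pair cannot assign the step to either part alone, and a single dose gives no measure of potency. As far as these compounds go, it also remains open whether a longer chain, or an amine in place of the nitrile, would keep this read-out, and whether hydrogen in place of methyl on the aromatic carbon would act in the same way on the core of compound 4.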